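Amino for chloro on the purine-type core of compound 1

The source may hold more compounds than are shown below. What is called first, only, known or untested is meant among the compounds shown, and "the series" means these compounds.

Measured so far:
compound 1 `ClCc1ccccc1Cn1cnc2c(Cl)nc(Cl)nc21` — 1470 nM
compound 2 `ClCc1cccc(Cn2cnc3ncnc(Cl)c32)c1` — 28800 nM

In a functional assay on BT-549 cells (Homo sapiens) for cytotoxicity, read by sulforhodamine B assay, with a stated time of 48 h (on this read-out higher numbers stand for weaker inhibition of growth and lower numbers for stronger inhibition of growth), compound 1 gives 1470 nM, the lowest of the two numbers. Compound 2 gives 28800 nM, a gap beyond the scatter; the two compounds differ in more than one place, so the pair says nothing about a single change.

Compound 3 `Nc1nc(Cl)c2ncn(Cc3ccccc3CCl)c2n1` has not been measured. It differs from compound 1 by amino in place of chloro on an aromatic carbon. For the measured compounds named here, no measured pair isolates this change, and the shared core is otherwise kept as in compound 1. With only the value of compound 1 1470 nM as anchor, a modest loss is expected for compound 3, with a step in this assay of a 2.4-fold higher number from compound 1 to compound 3 (0.38 log units; beyond the scatter) toward higher concentration, though a result within the scatter would not surprise. The estimate for compound 3 is 3500 nM, in the range 1000 nM to 15000 nM.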

Compound 3, concentration for total growth inhibition: 22900 nM
Beside the measured number, compound 3's estimate is 6.5-fold (0.82 log units) below it; the whole stated range lies below it.
By their numbers in this assay, from the lowest: compound 1; then compounds 3 and 2 (each within the scatter of the next).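

In this assay, for the compounds shown here, this is the first change that can be read alone: amino in place of chloro on the aromatic carbon between two ring nitrogen atoms gives a 16-fold higher number from compound 1 to compound 3 (1.19 log units; beyond the scatter). The step is large and beyond the scatter, so this position is not indifferent to the group it carries, and chloro and amino are not interchangeable here on this read-out. Nothing measured bears on what lies behind the step, so it stands as an observation only.

The compounds shown leave open whether the step reflects the loss of chloro or the entry of amino, a question that a methoxy or a methylamino group at the same carbon could help to separate. They also leave open whether the same step would hold with the chloromethyl group elsewhere on the benzene ring.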